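The source may hold more compounds than are shown below. What is called first, only, known or untested is meant among the compounds shown, and "the series" means these compounds.

Working notes on the series. In an ADME assay on HCT-116 cells (Homo sapiens) for cytotoxicity, read by CellTiter-Glo, with a stated time of 72 h (on this read-out lower numbers stand for stronger inhibition and higher numbers for weaker inhibition), compound 1 `Cc1cc(C)c(S(=O)(=O)N2CCC(C(=O)N3CCC(C)CC3)CC2)c(C)c1` gives > 5000 nM, which is a limit of the assay and not a number. Compound 2 `CC1CCN(C2CCN(S(=O)(=O)c3cccnc3F)CC2)CC1` gives > 10000 nM in this assay, again a limit rather than a number. Compound 3 `COc1ccc(NC(=O)N2CCC(N3CCC(C)CC3)CC2)cc1` gives > 5000 nM in this assay, also a limit. Compound 1 therefore stands at the limit of > 5000 nM in this assay, at which 2 of the 3 values shown sit. The remaining reading sits at the limit of > 10000 nM in this assay, at which 1 of the 3 values shown sits. Among the compounds with values here, no pair among compounds 1, 2 and 3 differs in one place, so no measured step is available; the three readings simply show no measurable inhibition for any of them.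

Compound 4 `CCCC(=O)NC1CCN(S(=O)(=O)c2c(C)cc(C)cc2C)CC1` is not yet measured in this assay. Relative to compound 1 it carries (propylcarbonyl)amino in place of (4-methylpiperidin-1-yl)carbonyl on a saturated ring carbon. The sulfonyl-bearing ring nitrogen and the aryl part of the core are kept, and the change exchanges one amide for another on the same saturated ring carbon.

Within the data shown here, with compound 1 at a limit and no measured step to lean on, the step that the limit leaves unreadable from compound 1 to compound 4 is expected to be none beyond the scatter, most likely returning a limit once more. Compound 4 is estimated at 15000 nM in this assay, with a range from 5000 nM to 60000 nM.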

Compound 4, half-maximal inhibitory concentration: > 5000 nM
Compound 4 gave a limit, no number (the forecaster's own chance of this, stated with the estimate: 85%); the middle value does not contradict the limit.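

Within the data shown here, compound 1 and compound 4 both stand at limits in this assay, not at numbers, so no step between them can be read. Most readings sit at the same limit: the limit of > 5000 nM in this assay, at which 3 of the 4 values shown sit.

The compounds shown leave open whether (propylcarbonyl)amino in place of (4-methylpiperidin-1-yl)carbonyl changes the read-out at all, and what number any of these compounds would give.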